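Ring Size and Growth Inhibition in Lung Cancer Cells

The compounds below may be only part of what the source reports. "The series", "measured", "known", "first", "only" and "open" are said of these compounds alone.

Compound 1 `COc1cccc(Nc2ncnc3cc(OC)c(OCCCN4CCNCCNCCNCC4)cc23)c1` in a functional assay on A549 cells (Homo sapiens) for antiproliferative activity, read by MTT assay, with a stated time of 72 h (a higher number here means a weaker inhibitor, a lower number a stronger inhibitor), gives > 50000 nM, a limit of the assay rather than a number.
Compound 2 `CCc1cc(Br)ccc1Nc1ncnc2cc(OC)c(OCCCN3CCNCCNCCNCC3)cc12` in this assay gives > 50000 nM, likewise only a limit.

Compound 2 therefore stands at the assay limit, as the limit of > 50000 nM in this assay, at which 2 of the 2 values shown sit, records. Going by the values given here, the single measured step, a step that the two limits leave unreadable from compound 1 to compound 2, cannot be read, so it offers no guidance. Compound 3 `CCc1cc(Br)ccc1Nc1ncnc2cc(OC)c(OCCCN3CCNCCNCC3)cc12` differs from compound 2 by a group of 9 heavy atoms (6 carbon, 3 nitrogen; one nine-membered non-aromatic ring with 3 hetero atoms) in place of a group of 12 heavy atoms (8 carbon, 4 nitrogen; one twelve-membered non-aromatic ring with 4 hetero atoms), on a saturated chain carbon, three bonds along the chain from an oxygen on an aromatic ring. Among the compounds with values here, no measured step bears on this change. Compound 3 is expected to remain at the limit, which corresponds to an expected step that the limit leaves unreadable from compound 2 to compound 3. The estimate for compound 3 is 80000 nM, ranging from 30000 nM to 250000 nM.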

Compound 3, half-maximal inhibitory concentration: > 50000 nM
Compound 3 ended at the assay's limit; the forecaster's own chance of this, stated with the estimate: 85%; the middle value does not contradict the limit.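

The step from compound 2 to compound 3 cannot be read, as both compounds give only a limit and not a number: the limit of > 50000 nM in this assay, at which 3 of the 3 values shown sit.

As far as these compounds go, whether ring size or the aromatic group on the nitrogen changes the activity at all remains open.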